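Swapping the ring amine substituent in an amidine series

The source may hold more compounds than are shown below. What is called first, only, known or untested is meant among the compounds shown, and "the series" means these compounds.

Of the compounds shown here, two that share one core have been measured in an assay on isolated protein for binding affinity to serine protease 1 (Homo sapiens); a higher number here means a weaker inhibitor, a lower number a stronger inhibitor. Compound 1, `N=C(N)c1cccc(C(=O)N[C@@H](C(=O)N2CCN(c3ccc(F)cc3)CC2)c2ccccc2)c1`, gives 1260 nM. Compound 2, `N=C(N)c1cccc(C(=O)N[C@@H](C(=O)N2CCN(c3ccncc3)CC2)c2ccccc2)c1`, gives 560 nM. These two differ only on an amine nitrogen in a ring, and the step is a 2.3-fold lower number from compound 1 to compound 2 (0.35 log units; beyond the scatter). For the measured compounds named here, on the numbers so far compound 2 therefore stands with the lower of the two values, its only neighbour being compound 1.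

Compound 3, `N=C(N)c1cccc(C(=O)N[C@@H](C(=O)N2CCN(C(=O)c3ccccc3)CC2)c2ccccc2)c1`, changes the same position once more: benzoyl in place of pyridin-4-yl on an amine nitrogen in a ring. Going by the values given here, no measured step covers this exact exchange; the one step in hand, a 2.3-fold lower number from compound 1 to compound 2 (0.35 log units; beyond the scatter), concerns a different pair of groups at that position and was modest in size. Among the compounds with values here, it shows only that this position tolerates change without a large shift. For compound 3 a step of a 1.3-fold higher number from compound 2 to compound 3 (0.10 log units; within the scatter) is therefore expected, that is, little movement beyond the scatter in either direction. Compound 3 is estimated at 700 nM in this assay, with a range from 250 nM to 2000 nM.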

Compound 3, inhibition constant: 460 nM
The estimate for compound 3 lay 1.5-fold (0.18 log units) above the measured number; measured number inside the range.
By their numbers in this assay, from the lowest: compounds 3 and 2 (each within the scatter of the next); then compound 1.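

For the compounds shown here, the earlier pair exchanged only one aromatic ring group for another, whereas benzoyl is a larger group that also carries a double bond outside aromatic rings. Even so, the change gives a 1.2-fold lower number from compound 2 to compound 3 (0.09 log units; within the scatter) in this assay, so this measurement cannot separate benzoyl from pyridin-4-yl on the ring amine nitrogen, and the position accepts a group of a different build without a large shift. Set against 4-fluorophenyl, the same group gives a 2.7-fold lower number from compound 1 to compound 3 (0.44 log units; beyond the scatter), which leaves compound 1 as the only one of the three set apart from the others, while nothing measured here accounts for these numbers.

Going by these compounds, all three groups at this position contain a six-membered aromatic ring, so it remains open whether such a ring is needed at all, a question that a small acetyl group or a plain ethyl chain on the same nitrogen would address. On these data alone, it is also open whether an amine or a carboxylic acid attached to the benzoyl ring would move the number beyond the scatter in either direction.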